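The source may hold more compounds than are shown below. What is called first, only, known or untested is meant among the compounds shown, and "the series" means these compounds.

Among the compounds with values here, compound 3 `Cc1nc(-c2ccccc2)c(C(=O)N2CCN(c3cc(Cl)cc(Cl)c3)CC2)o1` gives 41.8 nM in a functional assay on HL-60 cells (Homo sapiens) for inhibition, read by MTT assay, with a stated time of 72 h (on this read-out higher numbers stand for weaker inhibition and lower numbers for stronger inhibition), which places it second highest of the three numbers measured so far. Compound 2 `Cc1cc(C)cc(N2CCN(C(=O)c3oc(C)nc3-c3ccccc3)CC2)c1` gives 34.5 nM in this assay, and compound 1 `Cc1nc(-c2ccccc2)c(C(=O)N2CCN(c3cccc(C(F)(F)F)c3)CC2)o1` gives 153 nM. Compound 4 `Cc1ccc(C)c(N2CCN(C(=O)c3oc(C)nc3-c3ccccc3)CC2)c1` differs from compound 3 by 2,5-dimethylphenyl in place of 3,5-dichlorophenyl on an amine nitrogen in a ring. The measured steps at this amine nitrogen were a 4.4-fold lower number from compound 1 to compound 2 (0.65 log units; beyond the scatter) and a 3.7-fold lower number from compound 1 to compound 3 (0.56 log units; beyond the scatter), while exchanging one of those groups for the other gave a 1.2-fold higher number from compound 2 to compound 3 (0.08 log units; within the scatter). Compound 2 carries a 3,5-dimethylphenyl rather than the 2,5-dimethylphenyl of compound 4, so compound 4 has no exact precedent among these. The step to compound 4 is nonetheless expected to be a 1.2-fold higher number from compound 3 to compound 4 (0.08 log units; within the scatter), not beyond the scatter. Compound 4 is therefore estimated at 50 nM, within a range from 20 nM to 150 nM.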

Compound 4, half-maximal inhibitory concentration: 31.3 nM
Estimate against measurement, compound 4: 1.6-fold (0.20 log units) above; the measured number falls inside the stated range.
By their numbers in this assay, from the lowest: compounds 4, 2 and 3 (each within the scatter of the next); then compound 1.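

In this assay the placing of the two methyl groups on the phenyl makes no readable difference, with a 1.1-fold lower number from compound 2 to compound 4 (0.04 log units; within the scatter) and, for the exchange of the 3,5-dichlorophenyl, a 1.3-fold lower number from compound 3 to compound 4 (0.13 log units; within the scatter) as well. Against the 3-(trifluoromethyl)phenyl of compound 1 the result is a 4.9-fold lower number from compound 1 to compound 4 (0.69 log units; beyond the scatter) and so compound 4 joins compound 2 and compound 3 in lying clearly lower, with none of the listed compounds going against this. No supporting evidence bears on why these steps come out as they do.

The compounds shown leave open where an unsubstituted phenyl or a 2,5-dichlorophenyl would fall at this amine nitrogen. They also leave open whether a methoxy group on the phenyl would keep the number as low as these three.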